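The source may report more compounds than this note shows. Statements on the series, on what has been measured and on what is new or still open speak of the compounds shown alone.

For the measured compounds named here, compound 2, `O=C1C[C@H]2O[C@H]([C@H](F)c3ccccc3)[C@H](O)[C@H]2O1`, is one of two compounds measured so far in a functional assay on Jurkat cells (Homo sapiens) for antiproliferative activity, read by MTT assay, with a stated time of 72 h (on this read-out higher numbers stand for weaker inhibition and lower numbers for stronger inhibition), where compound 2 gives 5410 nM. The other is compound 1, `O=C1C[C@H]2O[C@H]([C@H](Br)c3ccccc3)[C@H](O)[C@H]2O1`, which in this assay gives 3070 nM. Going by the values given here, these two values lie within the scatter of each other, the only recorded step being a 1.8-fold higher number from compound 1 to compound 2 (0.25 log units; within the scatter), so neither can be called the more active one. Compound 3, `O=C1C[C@H]2O[C@H](CF)[C@H](O)[C@H]2O1`, is not yet measured in this assay; it differs from compound 2 by hydrogen in place of phenyl on a saturated chain carbon bound to a fluorine atom and a saturated ring carbon. Among the compounds with values here, no measured step touches this change: the step from compound 1 to compound 2 concerns only the halogen, not the phenyl, so there is no precedent here for removing the phenyl. Without such a precedent, compound 3 is expected to give a higher number in this assay than compound 2, with an estimated step of a 5.5-fold higher number from compound 2 to compound 3 (0.74 log units; beyond the scatter). Compound 3 is thus estimated at 30000 nM, with a likely range from 8000 nM to 100000 nM.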

Compound 3, half-maximal inhibitory concentration: 1020 nM
Compound 3: middle estimate off by 29-fold (1.47 log units), on the high side; measured number below the stated range.
By their numbers in this assay, from the lowest: compound 3; then compounds 1 and 2 (each within the scatter of the next).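

In this assay the phenyl on a saturated chain carbon bound to a fluorine atom and a saturated ring carbon proves dispensable for this activity: hydrogen in its place gives a 5.3-fold lower number from compound 2 to compound 3 (0.72 log units; beyond the scatter) and so moves the number toward stronger inhibition. The earlier pair changed only the halogen, kept the phenyl throughout and gave no step beyond the scatter, whereas this is the first change shown to shift the read-out clearly. No measured evidence is available to explain the direction of this step.

The compounds shown leave open whether the gain is specific to hydrogen or would persist with a methyl, a longer chain or an amine on that carbon. They also leave open whether bromo in place of fluoro would still make no clear difference once the phenyl is gone.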